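The source may hold more compounds than are shown below. What is called first, only, known or untested is meant among the compounds shown, and "the series" means these compounds.

Compound 1, `COc1ccc([C@H]2CC(=O)N(c3ccccc3C(F)(F)F)C2)cc1OC1CCCC1`. In a functional assay on HEK293 cells (Homo sapiens) for cytotoxicity (a lower number here means that less compound is tolerated, a higher number that more compound is tolerated), compound 1 gives > 10000 nM.
Compound 2, `COc1ccc(S(=O)(=O)Nc2cccc(N3C[C@@H](c4ccc(OC)c(OC5CCCC5)c4)CC3=O)c2)cc1`. In this assay compound 2 gives > 10000 nM.

The value of compound 1 is a limit of the assay, not a measured number. The value of compound 2 is likewise a limit of the assay, not a measured number. Compound 2 therefore stands at the limit of > 10000 nM in this assay, at which 2 of the 2 values shown sit, and nothing separates it from compound 1 on the numbers shown: both compounds were tolerated by the cells up to the highest concentration tested, and no difference between them can be read.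

Compound 3, `COc1ccc([C@H]2CC(=O)N(c3cccc(NS(=O)(=O)c4cccc(C)c4)c3)C2)cc1OC1CCCC1`, has not yet been measured. It differs from compound 2 in one place, (3-methylphenyl in place of 4-methoxyphenyl on a sulfonyl sulfur). No step between two measured compounds is shown here, so there is no measured change to lean on. With both measured compounds sitting at the limit, the expectation is that the change from compound 2 to compound 3 produces no step beyond the scatter, so that a step that the limit leaves unreadable from compound 2 to compound 3 is expected to be close to nothing. Compound 3 is accordingly estimated at 15000 nM, with a range from 7000 nM to 40000 nM, most likely reported again as a limit.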

Compound 3, half-maximal cytotoxic concentration: > 10000 nM
Compound 3 ended at the assay's limit (the forecaster's own chance of this, stated with the estimate: 80%); the middle value is on the limit's open side.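

Compound 2 and compound 3 both sit at a limit of the assay rather than at a measured number, so putting 3-methylphenyl in place of 4-methoxyphenyl gives no step that can be read: the limit of > 10000 nM in this assay, at which 3 of the 3 values shown sit.

The compounds shown leave open where any of them would reach a real value in this assay, and whether their structural differences matter there at all.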